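The compounds below may be only part of what the source reports. "The series", "measured", "known", "first", "only" and "open" are said of these compounds alone.

Series notes. Compound 1 `COc1cccc(C(=O)c2ccc3c(ccn3S(=O)(=O)c3cccc(/C=C/C(=O)NO)c3)c2)c1` and compound 2 `Cc1ccc(C(=O)c2ccc3c(ccn3S(=O)(=O)c3cccc(/C=C/C(=O)NO)c3)c2)cc1` share one core; compound 3 `Cc1ccc(C(=O)c2ccc3c(ccn3Cc3ccc(C(=O)NO)cc3)c2)cc1` and compound 4 `COc1cccc(C(=O)c2ccc3c(ccn3Cc3ccc(C(=O)NO)cc3)c2)c1` share another, and the difference between the two cores is not broken down here. In an assay on isolated protein for inhibition of polyamine deacetylase HDAC10 (Homo sapiens) (a lower number here means a stronger inhibitor, a higher number a weaker inhibitor), compound 1 gives 7740 nM and compound 2 gives 9100 nM. The change between them, (3-methoxyphenyl in place of 4-methylphenyl on a carbonyl carbon), yields a 1.2-fold lower number from compound 2 to compound 1 (0.07 log units; within the scatter). For compound 3 this assay reports only a limit, > 100000 nM, which is the limit of > 100000 nM in this assay, at which 1 of the 3 values shown sits. The same change, (3-methoxyphenyl in place of 4-methylphenyl on a carbonyl carbon), separates compound 3 from compound 4 at the same place on the carbonyl carbon. Compound 4 is expected near 150000 nM. Compound 4 is expected to fall between 50000 nM and 500000 nM. The expected step that the limit leaves unreadable from compound 3 to compound 4 rests on the measured step of a 1.2-fold lower number from compound 2 to compound 1 (0.07 log units; within the scatter) lying within the scatter, so a limit rather than a number is again expected for compound 4.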

Compound 4, half-maximal inhibitory concentration: 47900 nM
Compound 4: the middle estimate sits 3.1-fold (0.50 log units) above what was measured; measured number below the stated range.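

In this assay the change from 4-methylphenyl to 3-methoxyphenyl on a carbonyl carbon gives an at least 2.0-fold lower number from compound 3 to compound 4 (0.31 log units; beyond the scatter), whereas on the other core it gives a 1.2-fold lower number from compound 2 to compound 1 (0.07 log units; within the scatter). The value of compound 3, > 100000 nM, is a limit and not a number. The step is therefore beyond the scatter on one core and within it on the other, but this does not show that the change acts differently on the two cores: the same change on two cores in this assay, a 1.2-fold lower number (0.07 log units; within the scatter) from compound 2 to compound 1 and an at least 2.0-fold lower number (0.31 log units; beyond the scatter) from compound 3 to compound 4; the limit leaves it open whether they differ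

The compounds shown leave open how much of the step belongs to the methoxy group and how much to its place on the ring, which 4-methoxyphenyl and 3-methylphenyl partners would separate. Also open, on these data alone, is whether the step would hold for a phenyl ring carrying an amine or a carboxylic acid.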